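This account rests on a few compounds, and the source may have more. Where it says the series, first, only, none or still open, it means among the compounds named here.

Measured compounds:
- compound 1 `O=C(O)C12CC(CN3CCC[C@H](O[C@H](CO)c4cc(Cl)cc(Cl)c4)[C@@H]3c3ccccc3)(C1)C2`: > 200000 nM
- compound 2 `Cc1cc(C(=O)O)ccc1CN1CCC[C@H](O[C@H](CO)c2cc(Cl)cc(Cl)c2)[C@@H]1c1ccc(F)cc1`: "nd" (no result reported)

The study concerns an assay on isolated protein for activation of cGMP-dependent protein kinase 1 (Homo sapiens), read by ADP-Glo, with stated times of 30 min and 2 h; on this read-out higher numbers stand for an effect only at larger amounts of compound and lower numbers for an effect already at smaller amounts. Compound 1 reaches only the limit of this assay, (the limit of > 200000 nM in this assay, at which 1 of the 2 values shown sits), so no number for it is known, only that the effect was not seen within the range tested. For compound 2 this assay gives no result. For the measured compounds named here, no pair of measured compounds differs in a single place, so no measured step sets the scale here.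

Compound 3 `OC[C@@H](O[C@H]1CCCN(Cc2ncc[nH]2)[C@H]1c1ccccc1)c1cc(Cl)cc(Cl)c1` differs from compound 1 by a group of 5 heavy atoms (3 carbon, 2 nitrogen; one five-membered aromatic ring with 2 hetero atoms) in place of a group of 8 heavy atoms (6 carbon, 2 oxygen; 2 four-membered non-aromatic rings of carbon only), on a saturated chain carbon bound to an amine nitrogen in a ring. With compound 1 sitting at a limit, the size and direction of the step in this assay cannot be read off any measured pair; the expectation is a step of an at least 2.0-fold lower number from compound 1 to compound 3 (0.30 log units; that floor lies within the scatter), and it is expected that compound 3 may again return only a limit. In this assay compound 3 is estimated at 100000 nM, within 10000 nM to 300000 nM.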

Compound 3, half-maximal effective concentration: > 200000 nM
Compound 3 ended at the assay's limit (the forecaster's own chance of this, stated with the estimate: 60%); at least 2.0-fold (0.30 log units) between middle value and limit.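

In this assay, for the compounds shown here, compound 1 and compound 3 both stop at a limit, so no step between them can be read: the limit of > 200000 nM in this assay, at which 2 of the 3 values shown sit. The compounds shown leave open whether any group on this saturated chain carbon gives a readable effect on the shared core.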